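The source may hold more compounds than are shown below. What is called first, only, known or untested is meant among the compounds shown, and "the series" means these compounds.

Measured in a functional assay on HCC827 cells (Homo sapiens) for antiproliferative activity, read by MTT assay, with a stated time of 72 h; a higher number here means a weaker inhibitor, a lower number a stronger inhibitor:
- compound 1 `CC(C)n1c(Sc2ccccc2)nc2cnc(Nc3ccc(N4CCN(C)CC4)cc3)nc21` gives 290 nM here
- compound 2 `CN(C)C1CCN(c2ccc(Nc3ncc4nc(Sc5ccccc5)n(C5CCOCC5)c4n3)cc2)CC1` gives 29.4 nM here

Compound 1 has the higher number of the two, and the gap to compound 2 lies beyond the scatter. Compound 3 `CN1CCN(c2ccc(Nc3ncc4nc(Sc5ccccc5)n([C@H]5CC[C@H](O)CC5)c4n3)cc2)CC1` carries 4-hydroxycyclohexyl in place of isopropyl on an aromatic nitrogen on the core of compound 1. Among the compounds with values here, the only guide is compound 2, at 29.4 nM with a six-membered non-aromatic ring on that nitrogen, though it also differs elsewhere. A drop in this assay beyond the scatter is expected, with an estimated 4.8-fold lower number from compound 1 to compound 3 (0.68 log units; beyond the scatter) for this change. For compound 3 the expected value is 60 nM, with 15 nM to 220 nM as the estimated range.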

Compound 3, half-maximal inhibitory concentration: 42.6 nM
Compound 3: the middle estimate sits 1.4-fold (0.15 log units) above what was measured, within the range that was stated.
By their numbers in this assay, from the lowest: compounds 2 and 3 (each within the scatter of the next); then compound 1.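

In this assay, 4-hydroxycyclohexyl in place of isopropyl on the aromatic nitrogen gives a 6.8-fold lower number from compound 1 to compound 3 (0.83 log units; beyond the scatter) with the rest of compound 1 unchanged. This position therefore takes a larger group, with a six-membered non-aromatic ring and a hydrogen-bond donor, without a loss in this read-out. Nothing at hand explains the step.

Still open, going by these compounds, is whether plain cyclohexyl gives a similar number, which would separate the contribution of the ring from that of the hydroxyl. Also open, on these data alone, is whether an amine in place of the hydroxyl preserves the step.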